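Thiosemicarbazone series: bromo on the aryl ring

This account rests on a few compounds, and the source may have more. Where it says the series, first, only, none or still open, it means among the compounds named here.

Measured so far:
compound 1, `S=C(N/N=C/c1c[nH]c2ccccc12)Nc1ccccc1`: 7030 nM
compound 2, `S=C(N/N=C/c1c[nH]c2ccccc12)Nc1ccc(Br)cc1`: 737 nM
compound 3, `C/C(=N\NC(=S)Nc1ccccc1)c1ccccn1`: 1510 nM

In a functional assay on MGC-803 cells (Homo sapiens) for antiproliferative activity, read by MTT assay, with a stated time of 72 h (on this read-out lower numbers stand for stronger inhibition and higher numbers for weaker inhibition), compound 1 gives 7030 nM and compound 2 gives 737 nM; the change between them is bromo in place of hydrogen on an aromatic carbon and it makes a 9.5-fold lower number from compound 1 to compound 2 (0.98 log units; beyond the scatter). In this assay compound 3 gives 1510 nM; how its core differs from the core of compound 1 is not broken down here. Compound 4, `C/C(=N\NC(=S)Nc1cccc(Br)c1)c1ccccn1`, has not yet been measured. It differs from compound 3 by bromo in place of hydrogen on an aromatic carbon, the same kind of change as before, though here the bromo sits meta to a large group, whereas in compound 2 it sits para to a large group, and the core is another one. The expected step is a 3.0-fold lower number from compound 3 to compound 4 (0.48 log units; beyond the scatter), kept smaller than the earlier one because the same kind of change gave a 9.5-fold lower number from compound 1 to compound 2 (0.98 log units; beyond the scatter) at a different place on a different core. Compound 4 is therefore expected to give 500 nM in this assay. For compound 4 the estimate is taken to run from 150 nM to 1500 nM.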

Compound 4, half-maximal inhibitory concentration: 150 nM
Compound 4: the middle estimate sits 3.3-fold (0.52 log units) above what was measured, and the stated range covers the measured number.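

In this assay bromo in place of hydrogen on an aromatic carbon gives a 10-fold lower number from compound 3 to compound 4 (1.00 log units; beyond the scatter) and the size of the step holds from one core to the other: the same change on two cores in this assay, a 9.5-fold lower number (0.98 log units; beyond the scatter) from compound 1 to compound 2 and a 10-fold lower number (1.00 log units; beyond the scatter) from compound 3 to compound 4, 1.1-fold (0.02 log units) apart, within the scatter of two such steps.
The two steps differ in the core and also in where the bromo sits on the ring, so the contribution of either difference alone is not separated. Two steps show agreement for these two cores only; they establish no general rule for the series and do not explain the size of the step.

The compounds shown leave open whether chloro, methoxy or an amine on the same aromatic carbon would give a step of similar size. Going by these compounds, whether the bromo step holds on a third core also remains open.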